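The source may hold more compounds than are shown below. What is called first, only, known or untested is meant among the compounds shown, and "the series" means these compounds.

Compound 1 `COc1cc(O)c(C(C)=O)cc1Br`: 31400000 nM
Compound 2 `CCOc1cc(OC)c(Br)cc1C(C)=O`: 36000000 nM

In a functional assay, read by spectrophotometry, with a stated time of 6 min (a lower number here means a stronger inhibitor, a higher number a weaker inhibitor), compound 2 gives 36000000 nM and stands level with compound 1, at 31400000 nM. Going by the values given here, these are the only two numbers available, and they lie within the scatter of each other.

Compound 3 `CCCCOc1cc(OC)c(Br)cc1C(C)=O` extends the ethoxy of compound 2 to butoxy: ethyl in place of hydrogen on a saturated chain carbon, two bonds along the chain from an oxygen on an aromatic ring.

Among the compounds with values here, only one measured step bears on this change: a 1.1-fold higher number from compound 1 to compound 2 (0.06 log units; within the scatter). That step put ethyl in place of hydrogen on an oxygen on an aromatic ring, whereas here the ethyl enters on a saturated chain carbon, so it is only a loose guide. On that single step, no change beyond the scatter is expected in this assay, though the range must stay wide. The expected result is a 1.1-fold lower number from compound 2 to compound 3 (0.05 log units; within the scatter). For compound 3 the estimate is 32000000 nM, with an expected range from 12000000 nM to 75000000 nM.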

Compound 3, half-maximal inhibitory concentration: 34100000 nM
For compound 3 the middle estimate is 1.1-fold (0.03 log units) below the measured one, within the range that was stated.
By their numbers in this assay, from the lowest: compounds 1, 3 and 2 (each within the scatter of the next).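

Compound 3 shows that the ethoxy position tolerates further growth along the chain in this assay: ethyl in place of hydrogen on a saturated chain carbon, two bonds along the chain from an oxygen on an aromatic ring, gives a 1.1-fold lower number from compound 2 to compound 3 (0.02 log units; within the scatter). Measured against the hydrogen on that oxygen, the whole butyl group gives a 1.1-fold higher number from compound 1 to compound 3 (0.04 log units; within the scatter), so the hydrogen, ethyl and butyl forms of this oxygen all stand level within the scatter. Until now only the ethyl had been seen there, and the chain itself had not been varied.

No measurement offers a reason for this flat result. As far as these compounds go, whether a longer chain, or an amine or a carboxylic acid carried at the end of the chain, would move the number beyond the scatter remains open.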